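The compounds below may be only part of what the source reports. "The series", "measured", "known", "first", "only" and "open" are said of these compounds alone.

Compound 1 `COc1cccc(C2=NN(C(=O)OCc3ccccc3)C(c3cc(OC)c(OC)c(OC)c3)C2)c1`: > 10000 nM (a limit)
Compound 2 `COC(=O)N1N=C(c2cccc(O)c2)CC1c1cc(OC)c(OC)c(OC)c1`: 3170 nM
Compound 3 `CCOC(=O)N1N=C(c2cccc(O)c2)CC1c1cc(OC)c(OC)c(OC)c1`: 5120 nM

In a functional assay on A549 cells (Homo sapiens) for antiproliferative activity, read by MTT assay, with a stated time of 48 h (a higher number here means a weaker inhibitor of growth, a lower number a stronger inhibitor of growth), compound 3 gives 5120 nM and stands within the scatter of compound 2. The value of compound 1 is a limit, not a number.

Compound 4 `COc1cc(C2CC(c3cccc(O)c3)=NN2C(=O)OCc2ccccc2)cc(OC)c1OC` keeps the core of compound 3, with one change: phenyl in place of methyl on a saturated chain carbon bound to an oxygen next to a carbonyl group. This places phenyl in place of methyl on a saturated chain carbon bound to an oxygen next to a carbonyl group, turning ethoxycarbonyl into benzyloxycarbonyl.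

One measured step acts at the same place: a 1.6-fold higher number from compound 2 to compound 3 (0.21 log units; within the scatter). It swaps hydrogen for methyl, a smaller change than this one, so it is only a loose guide. Compound 1 also carries benzyloxycarbonyl, and its > 10000 nM is a limit.

In this assay, no step beyond the scatter is expected, though a higher number is the likelier direction, and compound 4 could also reach the limit. The estimate implies an expected 1.4-fold higher number from compound 3 to compound 4 (0.14 log units; within the scatter). For compound 4 the estimated value is 7000 nM, with an expected range of 2500 nM to 20000 nM.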

Compound 4, concentration for 50% growth inhibition: > 10000 nM
Compound 4 gave a limit, no number (the forecaster's own chance of this, stated with the estimate: 30%); middle value at least 1.4-fold (0.15 log units) from the limit.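

Putting phenyl in place of methyl, which turns ethoxycarbonyl into benzyloxycarbonyl, gives an at least 1.9-fold higher number from compound 3 to compound 4 (0.29 log units; that floor lies within the scatter) in this assay, so this comparison alone does not clear the scatter. The comparison with the smallest group shown at this place does clear it, with an at least 3.1-fold higher number from compound 2 to compound 4 (0.49 log units; beyond the scatter), whereas the earlier step of a 1.6-fold higher number from compound 2 to compound 3 (0.21 log units; within the scatter) did not, so a real loss of growth inhibition at this position appears only with the benzyl group. The step between compound 1 and compound 4 cannot be read, with both values being limits: the limit of > 10000 nM in this assay, at which 2 of the 4 values shown sit.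

Going by these compounds, the true size of the loss for compound 4 stays open. A longer chain such as propyl or butyl at this place, or an amine on that chain, would test whether the loss follows chain length or needs the phenyl ring.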